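Swapping the hydroxyphenyl of compound 1 for chlorophenyl

This account rests on a few compounds, and the source may have more. Where it says the series, first, only, none or still open, it means among the compounds named here.

Measured compounds:
- compound 1 `O=C1/C(=C\c2ccc(O)cc2)c2ccccc2N1c1c(Cl)cccc1Cl`: 2 ug/mL
- compound 2 `Cc1ccc2nc(Cl)c(/C=C3\C(=O)N(c4c(Cl)cccc4Cl)c4ccccc43)cc2c1C`: 10 ug/mL

In a functional assay on KB cells (Homo sapiens) for cytotoxicity, read by MTT assay, with a stated time of 72 h (on this read-out lower numbers stand for an effect already at smaller amounts and higher numbers for an effect only at larger amounts of compound), compound 1 gives the lower of the two numbers, and compound 2 sits beyond the scatter above it. Compound 3 `O=C1/C(=C\c2cccc(Cl)c2)c2ccccc2N1c1c(Cl)cccc1Cl` is not yet measured; it differs from compound 1 by 3-chlorophenyl in place of 4-hydroxyphenyl on a double-bonded chain carbon bound to a double-bonded ring carbon. Among the compounds with values here, no measured pair shows this kind of change, so its direction is uncertain; a modest rise in the number, somewhat beyond the scatter, is expected, namely a 2.5-fold higher number from compound 1 to compound 3 (0.40 log units; beyond the scatter). Compound 3 is therefore estimated at 5 ug/mL, with a range from 1.5 ug/mL to 15 ug/mL.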

Compound 3, concentration for half-maximal effect: 2 ug/mL
The estimate for compound 3 lay 2.5-fold (0.40 log units) above the measured number; low and high end bracket the measured number.
By their numbers in this assay, from the lowest: compounds 1 and 3 (each within the scatter of the next); then compound 2.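

In this assay putting 3-chlorophenyl in place of 4-hydroxyphenyl on a double-bonded chain carbon bound to a double-bonded ring carbon gives no change at the digits printed from compound 1 to compound 3 (within the scatter) and so shows that this place tolerates this change. The entering group has 0 hydrogen-bond donors and 0 hydrogen-bond acceptors, so in this pair the number does not depend on keeping the hydroxyl. No measurement here explains why the two numbers match. On these data alone, whether an amine or a carboxylic acid on this phenyl would give a similar number remains open. So does the comparison with 4-chlorophenyl, which would separate the change of group from the change in its ring position.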